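The source may report more compounds than this note shows. Statements on the series, on what has been measured and on what is new or still open speak of the compounds shown alone.

In a functional assay on V79 cells (Cricetulus griseus) for cytotoxicity, read by colony formation (on this read-out higher numbers stand for weaker inhibition and lower numbers for stronger inhibition), three compounds have been measured. Compound 1 `O=C(O)c1cn(C2CC2)c2c(Cl)c(N3CCCC3)c(F)cc2c1=O` gives 150 ug/mL in this assay. Compound 2 `COc1c(N2CCCC2)c(F)cc2c(=O)c(C(=O)O)cn(C3CC3)c12` differs from compound 1 by methoxy in place of chloro on an aromatic carbon, and in this assay compound 2 gives 150 ug/mL, a step of no change at the digits printed from compound 1 to compound 2 (within the scatter). Compound 3 `NC1CCCN(c2c(F)cc3c(=O)c(C(=O)O)cn(C4CC4)c3c2Cl)C1` carries a different ring on the shared core, and in this assay compound 3 gives 24 ug/mL, a step of a 6.3-fold lower number from compound 1 to compound 3 (0.80 log units; beyond the scatter). Of the three numbers, compound 3 stands at the lowest, with both compound 1 and compound 2 beyond the scatter above it.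

Compound 4 `COc1c(N2CCCC(N)C2)c(F)cc2c(=O)c(C(=O)O)cn(C3CC3)c12` has not been measured yet. It differs from compound 3 by methoxy in place of chloro on an aromatic carbon. Within the data shown here, this is the same kind of change as the one from compound 1 to compound 2, but not the same: around the place, in compound 3 it is ortho to a 3-aminopiperidin-1-yl group, whereas in compound 1 it is ortho to a pyrrolidin-1-yl group. The cores of compound 1 and compound 3 differ by 3-aminopiperidin-1-yl in place of pyrrolidin-1-yl on an aromatic carbon.

Because the matching step from compound 1 to compound 2 gave no change at the digits printed from compound 1 to compound 2 (within the scatter), the step from compound 3 to compound 4 in this assay is expected to be no change at the digits printed from compound 3 to compound 4 (within the scatter). Compound 4 is therefore estimated at 24 ug/mL, with a likely range from 10 ug/mL to 60 ug/mL.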

Compound 4, half-maximal inhibitory concentration: 69 ug/mL
Estimate against measurement, compound 4: 2.9-fold (0.46 log units) below, and the stated range ends below it.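

With the 3-aminopiperidin-1-yl group on the core, methoxy in place of chloro in this assay gives a 2.9-fold higher number from compound 3 to compound 4 (0.46 log units; beyond the scatter), so a change that left the pyrrolidin-1-yl pair level does not carry over to this core unaltered: the same change on two cores in this assay, no change at the digits printed (within the scatter) from compound 1 to compound 2 and a 2.9-fold higher number (0.46 log units; beyond the scatter) from compound 3 to compound 4, 2.9-fold (0.46 log units) apart, beyond the scatter of two such steps

Read the other way, 3-aminopiperidin-1-yl in place of pyrrolidin-1-yl still lowers the number when methoxy is present, with a 2.2-fold lower number from compound 2 to compound 4 (0.34 log units; beyond the scatter), but the drop is smaller than when chloro is present: the same change on two cores in this assay, a 6.3-fold lower number (0.80 log units; beyond the scatter) from compound 1 to compound 3 and a 2.2-fold lower number (0.34 log units; beyond the scatter) from compound 2 to compound 4, 2.9-fold (0.46 log units) apart, beyond the scatter of two such steps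

The direction of the ring swap therefore held in both pairs while its size did not, which means the two changes do not simply add up, but these four compounds do not show why this happens or how the swap from chloro to methoxy would behave on any other core.

The compounds shown leave open whether the same dependence would appear with another group in place of chloro or methoxy, such as bromo or ethoxy, or with another amine in place of 3-aminopiperidin-1-yl, such as piperazin-1-yl. They also leave open whether the pattern would hold on a read-out other than this assay.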